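The source may report more compounds than this note shows. Statements on the series, on what has been measured and on what is new or still open speak of the compounds shown alone.

Working notes on a small set of chlorinated cores, all tested in a functional assay on RPMI-8226 cells (Homo sapiens) for cytotoxicity, read by sulforhodamine B assay, with a stated time of 48 h; on this read-out higher numbers stand for weaker inhibition of growth and lower numbers for stronger inhibition of growth. Compound 1 `ClCc1cccc(Cn2cnc3ncnc(Cl)c32)c1` gives 13800 nM in this assay. Compound 2 `ClCc1cccc(Cn2cnc3c(Cl)ncnc32)c1` gives 3800 nM; the difference between the core of compound 1 and the core of compound 2 is not broken down here. Compound 3 `ClCc1cccc(Cn2cnc3c(Cl)nc(Cl)nc32)c1` gives 3310 nM. The change from compound 2 to compound 3 is chloro in place of hydrogen on an aromatic carbon, and the step it made is a 1.1-fold lower number from compound 2 to compound 3 (0.06 log units; within the scatter). Compound 4 `ClCc1cccc(Cn2cnc3nc(Cl)nc(Cl)c32)c1` is not yet measured in this assay; it differs from compound 1 by chloro in place of hydrogen on an aromatic carbon, the same change as that from compound 2 to compound 3. Because the step of a 1.1-fold lower number from compound 2 to compound 3 (0.06 log units; within the scatter) lies within the scatter, a step of similar size is expected from compound 1 to compound 4, namely a 1.2-fold lower number from compound 1 to compound 4 (0.06 log units; within the scatter). Compound 4 is accordingly estimated at 12000 nM, with an expected span from 5000 nM to 30000 nM.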

Compound 4, concentration for 50% growth inhibition: 1690 nM
Compound 4: middle estimate off by 7.1-fold (0.85 log units), on the high side; the whole stated range lies above it.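

In this assay, chloro in place of hydrogen on an aromatic carbon gave an 8.2-fold lower number from compound 1 to compound 4 (0.91 log units; beyond the scatter). Among the compounds shown here, the size of this change therefore does not carry over unchanged from one core to the other: the same change on two cores in this assay, a 1.1-fold lower number (0.06 log units; within the scatter) from compound 2 to compound 3 and an 8.2-fold lower number (0.91 log units; beyond the scatter) from compound 1 to compound 4, 7.1-fold (0.85 log units) apart, beyond the scatter of two such steps This rests on only two pairs, and it shows neither why the two cores respond differently nor what size the change would have on any further core.

Still open, as far as these compounds go, is whether an amine or a methoxy group at the same place would also give steps that differ between the two cores. Also open, from the compounds shown here alone, is how growth inhibition responds when the chloromethyl group shared by all four compounds gives way to a hydroxymethyl group or a longer chain.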